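Permeability notes: from compound 2 to compound 4

A few compounds are considered here, and "the series" means these few. Any claim that something is new, unique, unknown or untested is made for them only; others in the source may bear on it.

Measured so far in an ADME assay on LLC-PK1 cells (Sus scrofa) for permeability; on this read-out higher numbers stand for higher permeability and lower numbers for lower permeability:
compound 1 `COc1ccccc1C(=O)NC(=O)Nc1ccc(N2CCCCC2)c(Cl)c1` gives < 1 10^-6 cm/s, which is a limit of the assay and not a number.
compound 2 `COc1ccccc1C(=O)NC(=O)Nc1ccc(-c2ccccn2)c(C(F)(F)F)c1` gives 7.4 10^-6 cm/s.
compound 3 `COc1ccccc1C(=O)NC(=S)Nc1ccc(N2CCCCC2)c(Cl)c1` gives 1.8 10^-6 cm/s.

Compound 2 stands highest of the two numbers in this assay; its nearest neighbour is compound 3, whose number sits below it by a gap beyond the scatter. Compound 1 sits at the limit of < 1 10^-6 cm/s in this assay, at which 1 of the 3 values shown sits. Within the data shown here, no pair among the measured compounds differs in one place only, so no single step in this assay is known.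

Compound 4 `COc1ccccc1C(=O)NC(=O)Nc1ccc(-c2nccs2)c(C(F)(F)F)c1` is not yet measured. It differs from compound 2 by 1,3-thiazol-2-yl in place of pyridin-2-yl on an aromatic carbon, on an aromatic carbon of a six-membered aromatic ring of carbon only, ortho to a trifluoromethyl group and para to a large group. The change is a swap of one small aromatic group for another; the step expected from compound 2 to compound 4 in this assay is a 1.2-fold lower number from compound 2 to compound 4 (0.09 log units; within the scatter), within the scatter or slightly downward. Compound 4 is estimated at 6 10^-6 cm/s, between 3 10^-6 cm/s and 12 10^-6 cm/s.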

Compound 4, apparent permeability in the LLC-PK1 assay: 12 10^-6 cm/s
Beside the measured number, compound 4's estimate is 2.0-fold (0.30 log units) below it; low and high end bracket the measured number.
By their numbers in the LLC-PK1 assay, from the lowest: compound 3; then compounds 2 and 4 (each within the scatter of the next). At a limit, below all of these: compound 1.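

In the LLC-PK1 assay, 1,3-thiazol-2-yl in place of pyridin-2-yl on this aromatic carbon, ortho to a trifluoromethyl group, gives a 1.6-fold higher number from compound 2 to compound 4 (0.21 log units; within the scatter), the only single step on permeability among the compounds shown. In a physicochemical assay for solubility (a higher number here means a more soluble compound, a lower number a less soluble compound), compound 2 gives 28 ug/mL and compound 4 gives 1.1 ug/mL. This one change therefore separates the two read-outs: the LLC-PK1 assay does not distinguish the pair, while the physicochemical assay shows a 25-fold lower number from compound 2 to compound 4 (1.41 log units; beyond the scatter).

From the compounds shown here alone, what a morpholine or a carboxylic acid at this place would give in the LLC-PK1 assay and in the physicochemical assay remains open. Going by these compounds, whether the same pair of steps would recur without the trifluoromethyl group also remains open.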